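The compounds below may be only part of what the source reports. "The series", "measured", "known", "first", "only" and "open" are said of these compounds alone.

Measured compounds:
Compound 1 `CCCCCCOc1c(-c2cc(OC)c(OC)c(OC)c2)oc2ccccc2c1=O`: > 50000 nM
Compound 2 `CCCC(C)Oc1c(-c2cc(OC)c(OC)c(OC)c2)oc2ccccc2c1=O`: > 50000 nM

In a functional assay on DU-145 cells (Homo sapiens) for antiproliferative activity, read by WST assay, with a stated time of 3 days (on this read-out lower numbers stand for stronger inhibition and higher numbers for weaker inhibition), compound 2 gives > 50000 nM, which is a limit and not a number. Compound 1 is also reported only as a limit, > 50000 nM. The record so far is the limit of > 50000 nM in this assay, at which 2 of the 2 values shown sit.

Compound 3 `CCN(CC)CCCCOc1c(-c2cc(OC)c(OC)c(OC)c2)oc2ccccc2c1=O` carries 4-(diethylamino)butyl in place of 1-methylbutyl on an oxygen on an aromatic ring. For the measured compounds named here, the only measured step is a step that the two limits leave unreadable from compound 1 to compound 2, with 1-methylbutyl in place of hexyl, and it offers no size to carry forward. The entering chain contains nitrogen, unlike hexyl or 1-methylbutyl, so it is a different kind of change from that step. Any readable move in this assay is expected to be towards stronger inhibition, though another limit remains possible. The expected change is an at least 5.0-fold lower number from compound 2 to compound 3 (0.69 log units; beyond the scatter). For compound 3 the estimate is 10000 nM, with an expected range from 2000 nM to 50000 nM.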

Compound 3, half-maximal inhibitory concentration: 13300 nM
Beside the measured number, compound 3's estimate is 1.3-fold (0.12 log units) below it, and the stated range covers the measured number.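

In this assay, for the compounds shown here, the position on an oxygen on an aromatic ring now gives a readable number for the first time, and it does so with 4-(diethylamino)butyl: the change to this chain gives an at least 3.7-fold lower number from compound 2 to compound 3 (0.57 log units; beyond the scatter), and diethylamino in place of ethyl on the chain gives an at least 3.7-fold lower number from compound 1 to compound 3 (0.57 log units; beyond the scatter). Both sizes are only lower bounds, as compound 1 and compound 2 are reported as limits, and the step between those two cannot be read. Among the three chains, only the one carrying nitrogen leaves the assay limit, which still holds hexyl and 1-methylbutyl: the limit of > 50000 nM in this assay, at which 2 of the 3 values shown sit.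

Going by these compounds, whether the amine itself or the chain length matters most stays open. A shorter 2-(diethylamino)ethyl chain, a pyrrolidine or morpholine at the chain end, or a terminal hydroxyl on the butyl chain could separate these.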